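The source may report more compounds than this note shows. Statements on the series, on what has been measured and on what is new or still open speak of the compounds shown alone.

Measured compounds:
- compound 1, `CCCCCCCCCCCOC(=O)CCC(=O)N1CCN(CCCOc2cc3c(Nc4ccc(F)c(Cl)c4)ncnc3cc2OC)CC1`, 85.2%
- compound 2, `CCCCCCCCCCCCCCCCOC(=O)CCC(=O)N1CCN(CCCOc2cc3c(Nc4ccc(F)c(Cl)c4)ncnc3cc2OC)CC1`, 91.7%
- compound 3, `CCCCCCCCCCCCCCCCCOC(=O)CCC(=O)N1CCN(CCCOc2cc3c(Nc4ccc(F)c(Cl)c4)ncnc3cc2OC)CC1`, 97.2%

In a functional assay on A549 cells (Homo sapiens) for cytotoxicity, read by MTT assay, with a stated time of 24 h, tested at 20 uM (on this read-out lower numbers stand for a stronger effect and higher numbers for a weaker effect at the one concentration tested), compound 3 stands at the highest of the three numbers. Its nearest neighbour is compound 2, and the gap between them, a number 5.5 percentage points higher from compound 2 to compound 3 (within the scatter), lies within the scatter. The furthest is compound 1, from which the step of a number 12 percentage points higher from compound 1 to compound 3 (beyond the scatter) goes beyond the scatter, while a number 6.5 percentage points higher from compound 1 to compound 2 (within the scatter) stays within it.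

Compound 4, `CCCCCCCCCCCCCCCCCCCCOC(=O)CCC(=O)N1CCN(CCCOc2cc3c(Nc4ccc(F)c(Cl)c4)ncnc3cc2OC)CC1`, is not yet measured. It differs from compound 3 by propyl in place of hydrogen on a saturated chain carbon, ten or more bonds along the chain from an oxygen next to a carbonyl group. The three measured steps all lengthen the same chain in this manner, and each raised the number; only the longest of them, from compound 1 to compound 3, exceeded the scatter.

A further lengthening of this kind is therefore expected to move compound 4 at most a little further in the same direction, probably within the scatter of compound 3, since the read-out is already near its top. Compound 4 is expected to give about 100%, between 90% and 110%, a step of a number 2.8 percentage points higher from compound 3 to compound 4 (within the scatter).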

Compound 4, a percentage reported as activity, at one concentration (the size of the read-out at that concentration, not a potency): 90.8%
Estimate against measurement, compound 4: 9.2 percentage points above; the range from low to high includes it.
By their numbers in this assay, from the lowest: compounds 1, 4, 2 and 3 (each within the scatter of the next, the first and the last beyond it).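

In this assay, lengthening the chain by propyl does not continue the run of rising numbers: the step is a number 6.4 percentage points lower from compound 3 to compound 4 (within the scatter). Against the shorter chains, the steps are a number 0.9 percentage points lower from compound 2 to compound 4 (within the scatter) and a number 5.6 percentage points higher from compound 1 to compound 4 (within the scatter), so compound 4 lies within the scatter of all three, and the only step beyond it remains a number 12 percentage points higher from compound 1 to compound 3 (beyond the scatter). Chain length at this position therefore gives no steady trend, and compound 4 goes against the earlier rise. Nothing available here bears on why these chains read as they do. The compounds shown leave open whether a branched chain, or a chain ending in an amine or a carboxylic acid, would read differently at this position. They also leave open how any of these chains behave at other concentrations in this assay.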